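The source may hold more compounds than are shown below. What is called first, only, known or untested is meant among the compounds shown, and "the series" means these compounds.

Compound 1 `O=C1NC(=S)/C(=C/c2ccc(Cl)cc2)S1`, compound 2 `O=C1NC(=S)/C(=C/c2ccccc2Cl)S1` and compound 3 `O=C1NC(=S)/C(=C/c2ccc(F)cc2)S1` share a core and were examined in a functional assay on HEp-2 cells (Homo sapiens) for cytotoxicity, read by MTT assay, with a stated time of 72 h, tested at 5 ug/mL; a lower number here means less inhibition of growth, a higher number more inhibition of growth at the concentration tested. Compound 1 gives 16.1%, compound 2 gives 5.97% and compound 3 gives 20.6%. Compound 2 holds the lowest of these three numbers, and both of its gaps to the others lie beyond the scatter. The difference between the cores of compound 2 and compound 1 is not broken down here. From compound 1 to compound 3 the change fluoro in place of chloro on an aromatic carbon produced a number 4.5 percentage points higher from compound 1 to compound 3 (within the scatter). The unmeasured compound 4 `O=C1NC(=S)/C(=C/c2ccccc2F)S1` carries the same kind of change relative to compound 2, namely (fluoro in place of chloro on an aromatic carbon), with the group ortho rather than para to the group of 8 heavy atoms. Because a number 4.5 percentage points higher from compound 1 to compound 3 (within the scatter) stayed within the scatter, a similarly small step is expected, a number 4 percentage points higher from compound 2 to compound 4 (within the scatter). Compound 4 is therefore estimated at 10% in this assay, likely between 2% and 20%.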

Compound 4, percent growth inhibition at one concentration: 8.86%
For compound 4 the middle estimate is 1.1 percentage points above the measured one; measured number inside the range.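

In this assay, within the data shown here, fluoro in place of chloro on an aromatic carbon gave a number 2.9 percentage points higher from compound 2 to compound 4 (within the scatter), and the two cores showed no difference in this step: the same change on two cores in this assay, a number 4.5 percentage points higher (within the scatter) from compound 1 to compound 3 and a number 2.9 percentage points higher (within the scatter) from compound 2 to compound 4, 1.6 percentage points apart, within the scatter of two such steps. On the cores of compound 1 and compound 2, the change therefore carried over as a small step. This does not show that the change would stay small on any other core, and neither step can be told from the usual scatter of the measurement.

The compounds shown leave open what an amine, a methoxy group or a carboxylic acid would do in place of the halogen. They also leave open whether the step would hold with a methyl group in place of the amide hydrogen of the shared core.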